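Chloro to Methyl on the Arylethenyl Ring of Compound 2

A few compounds are considered here, and "the series" means these few. Any claim that something is new, unique, unknown or untested is made for them only; others in the source may bear on it.

The compounds measured so far are:
compound 1, `COc1ccc(-c2cc(/C=C/C(=O)c3cc(OC)c(OC)c(OC)c3)nc3cc(-c4ccccc4)nn23)cc1OC`, with 8300 nM in a functional assay on DU-145 cells (Homo sapiens) for antiproliferative activity, read by MTT assay, with a stated time of 24 h; on this read-out higher numbers stand for weaker inhibition and lower numbers for stronger inhibition;
compound 2, `COc1cc(-c2cc(C(=O)/C=C/c3ccc(Cl)cc3)nc3cc(-c4ccccc4)nn23)cc(OC)c1OC`, with 19500 nM;
compound 3, `COc1ccc(-c2cc(/C=C/C(=O)c3ccc(C)c(C)c3)nc3cc(-c4ccccc4)nn23)cc1OC`, with 12100 nM.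

Compound 2 gives the largest of the three numbers, but its gap to compound 3 is within the scatter, while its gap to compound 1 lies beyond it. The new compound 4, `COc1cc(-c2cc(C(=O)/C=C/c3ccc(C)cc3)nc3cc(-c4ccccc4)nn23)cc(OC)c1OC`, differs from compound 2 by methyl in place of chloro on an aromatic carbon. For the measured compounds named here, the only measured step, a 1.5-fold higher number from compound 1 to compound 3 (0.16 log units; within the scatter), concerns a change at the carbonyl-bearing ring, not the arylethenyl ring, and it stayed within the scatter; no measured pair shows what a swap on the arylethenyl ring does. Going by the values given here, with nothing bearing directly on this change, and the one comparable exchange being flat, compound 4 is expected to stay close to compound 2, giving an estimated step of a 1.0-fold higher number from compound 2 to compound 4 (0.01 log units; within the scatter). Compound 4 is therefore estimated at 20000 nM, with a range from 8000 nM to 50000 nM.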

Compound 4, half-maximal inhibitory concentration: 21900 nM
Compound 4: middle estimate off by 1.1-fold (0.04 log units), on the low side, and the stated range covers the measured number.
By their numbers in this assay, from the lowest: compounds 1, 3, 2 and 4 (each within the scatter of the next, the first and the last beyond it).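

For the compounds shown here, the step from chloro to methyl on the 2-(4-chlorophenyl)ethenyl group gives a 1.1-fold higher number from compound 2 to compound 4 (0.05 log units; within the scatter) in this assay, and it is the first measured exchange on this ring, as the earlier step concerned only the carbonyl-bearing ring. At this place, para to a large group, chloro and methyl therefore cannot be told apart on this read-out. Nothing at hand offers an explanation for this result.

What an amine, a carboxylic acid or a longer chain such as butyl would do at this same place remains open; chloro and methyl are the only two groups shown there. Equally open, from the compounds shown here alone, is whether this exchange would read the same in compounds built like compound 1 and compound 3, where the carbonyl and the ethenyl stand the other way round.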